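Capping the free amine of compound 2

The compounds below may be only part of what the source reports. "The series", "measured", "known", "first", "only" and "open" are said of these compounds alone.

Measured so far in a toxicity assay on KB cells (Homo sapiens) for cytotoxicity, read by fluorescence, with a stated time of 3 days; on this read-out lower numbers stand for an effect already at smaller amounts and higher numbers for an effect only at larger amounts of compound:
- compound 1 `CCCCOC(=O)CNC(=O)[C@H](CSc1ccc([N+](=O)[O-])cc1[N+](=O)[O-])NC(=O)CC[C@H](NC(=O)c1ccccc1)C(=O)OCCCC`: > 300 uM (a limit)
- compound 2 `CCCCOC(=O)CNC(=O)[C@H](CSc1ccc([N+](=O)[O-])cc1[N+](=O)[O-])NC(=O)CC[C@H](N)C(=O)OCCCC`: 107 uM

For the measured compounds named here, compound 2 gives the only actual number so far. Compound 1 stands at a limit, (the limit of > 300 uM in this assay, at which 1 of the 2 values shown sits).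

Compound 3 `CCCCOC(=O)CNC(=O)[C@H](CSc1ccc([N+](=O)[O-])cc1[N+](=O)[O-])NC(=O)CC[C@H](Nc1ccc([N+](=O)[O-])cc1[N+](=O)[O-])C(=O)OCCCC` carries 2,4-dinitrophenyl in place of hydrogen on an amine nitrogen, that is, 2,4-dinitrophenyl in place of hydrogen on an amine nitrogen. Going by the values given here, the one measured change at this nitrogen is an at least 2.8-fold lower number from compound 1 to compound 2 (0.44 log units; beyond the scatter), and it involves benzoyl, a different group. Reversing that direction, a modest rise in this assay is expected, on weak support. Compound 3 is estimated at 160 uM, with a range of 40 uM to 400 uM. This is an expected 1.5-fold higher number from compound 2 to compound 3 (0.17 log units; within the scatter).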

Compound 3, concentration for half-maximal effect: > 300 uM
Compound 3 gave a limit, no number; the forecaster's own chance of this, stated with the estimate: 30%; middle value at least 1.8-fold (0.27 log units) from the limit.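

In this assay, a second group on this amine nitrogen moves the read-out the same way as benzoyl, with 2,4-dinitrophenyl in place of hydrogen giving an at least 2.8-fold higher number from compound 2 to compound 3 (0.44 log units; beyond the scatter). The earlier step is therefore not particular to benzoyl, and among the compounds shown only the free amine gives an actual number. The step between the two capped compounds cannot be read, as both values are limits: the limit of > 300 uM in this assay, at which 2 of the 3 values shown sit.

As far as these compounds go, how much either group raises the number remains open. From the compounds shown here alone, whether a smaller group such as methyl or acetyl on this nitrogen also gives a higher number is equally open.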